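Hydroxyphenyl position swap on the trifluoromethoxy analogue

The compounds below may be only part of what the source reports. "The series", "measured", "known", "first", "only" and "open" are said of these compounds alone.

The series shares the core of compound 1 `Oc1cccc(-c2cc(-c3cccc(F)c3)cc(-c3ccccc3O)n2)c1`. In a functional assay on HCT-15 cells (Homo sapiens) for inhibition (on this read-out lower numbers stand for stronger inhibition and higher numbers for weaker inhibition), compound 1 gives only a limit, > 50000 nM. Compound 2 `Oc1ccc(-c2cc(-c3cccc(C(F)(F)F)c3)cc(-c3cccc(O)c3)n2)cc1` gives 9540 nM in this assay. Compound 3 `Oc1cccc(-c2cc(-c3cccc(OC(F)(F)F)c3)cc(-c3ccccc3O)n2)c1` gives 2740 nM, the lowest of the two numbers, with compound 2 sitting above it beyond the scatter. Among the measured compounds shown here, the one measured step, an at least 18-fold lower number from compound 1 to compound 3 (1.26 log units; beyond the scatter), concerns a different group. Compound 1 stands at the limit of > 50000 nM in this assay, at which 1 of the 3 values shown sits.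

Compound 4 `Oc1ccc(-c2cc(-c3cccc(OC(F)(F)F)c3)cc(-c3cccc(O)c3)n2)cc1` differs from compound 3 by 4-hydroxyphenyl in place of 2-hydroxyphenyl on an aromatic carbon. For the measured compounds named here, no measured step bears on this change; compound 2 and compound 3 differ in two places at once, so their values give no isolated read. No step beyond the scatter is therefore expected in this assay. Compound 4 is estimated at 3500 nM, within 1000 nM to 12000 nM. The expected step is a 1.3-fold higher number from compound 3 to compound 4 (0.11 log units; within the scatter).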

Compound 4, half-maximal inhibitory concentration: 1730 nM
For compound 4 the middle estimate is 2.0-fold (0.31 log units) above the measured one; the range from low to high includes it.
By their numbers in this assay, from the lowest: compounds 4 and 3 (each within the scatter of the next); then compound 2. At a limit, above all of these: compound 1.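

In this assay, 4-hydroxyphenyl in place of 2-hydroxyphenyl at this position gives a 1.6-fold lower number from compound 3 to compound 4 (0.20 log units; within the scatter), so the two groups are not told apart here with trifluoromethoxy in the molecule. Trifluoromethoxy in place of trifluoromethyl gives a 5.5-fold lower number from compound 2 to compound 4 (0.74 log units; beyond the scatter), which points the same way as the earlier step from fluoro, with no compound shown against it. Nothing shown gives a reason for either step.

Going by these compounds, whether the swap reads the same with fluoro or trifluoromethyl in place of trifluoromethoxy stays open. So does the effect of an amine or a carboxylic acid in place of the hydroxyl.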